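The source may hold more compounds than are shown below. What is called first, only, known or untested is meant among the compounds shown, and "the series" means these compounds.

Working notes on the series. In an ADME assay on HEK293 cells (Homo sapiens) for cytotoxicity, read by MTT assay, with a stated time of 72 h (on this read-out higher numbers stand for weaker inhibition and lower numbers for stronger inhibition), compound 1 `COc1ccc(/C=C/c2cc(C)no2)cc1OC` gives 63200 nM and compound 3 `COc1ccc(/C=C/c2cc(C)no2)cc1` gives 58300 nM. These two values lie within the scatter of each other, and together they form the high end of the three numbers. Compound 2 `COc1ccc(/C=C/C(=O)CC(C)=O)cc1` gives a clearly lower number, 18700 nM.

The next structure is compound 4 `COc1ccc(/C=C/c2cc(C)n[nH]2)cc1OC`, and the change from compound 1 is 3-methyl-1H-pyrazol-5-yl in place of 3-methyl-1,2-oxazol-5-yl on a double-bonded chain carbon bound to a double-bonded chain carbon. This places 3-methyl-1H-pyrazol-5-yl in place of 3-methyl-1,2-oxazol-5-yl on a double-bonded chain carbon bound to a double-bonded chain carbon.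

For the measured compounds named here, the only measured single-place step is a 1.1-fold lower number from compound 1 to compound 3 (0.04 log units; within the scatter). It is within the scatter, but it concerns hydrogen in place of methoxy on an aromatic carbon, so it says nothing directly about this exchange. Going by the values given here, no measured pair tests the exchange itself. Compound 2, at 18700 nM, carries no five-membered aromatic ring and differs from compound 1 in more than one place, so it offers only a weak hint towards a lower number.

In this assay, the expected change is therefore small, with a slight lean downward and nothing expected beyond the scatter: a 1.5-fold lower number from compound 1 to compound 4 (0.18 log units; within the scatter). For compound 4, the estimated value is 42000 nM, with an expected range of 15000 nM to 100000 nM.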

Compound 4, half-maximal inhibitory concentration: 23200 nM
Compound 4: middle estimate off by 1.8-fold (0.26 log units), on the high side, and the stated range covers the measured number.
By their numbers in this assay, from the lowest: compounds 2 and 4 (each within the scatter of the next); then compounds 3 and 1 (each within the scatter of the next).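

In this assay the ring on the double-bonded chain carbon proves to matter: 3-methyl-1H-pyrazol-5-yl in place of 3-methyl-1,2-oxazol-5-yl gives a 2.7-fold lower number from compound 1 to compound 4 (0.44 log units; beyond the scatter) and so moves the number beyond the scatter, whereas the earlier step of a 1.1-fold lower number from compound 1 to compound 3 (0.04 log units; within the scatter) concerned hydrogen in place of methoxy on an aromatic carbon and stayed within it. The two rings match in heavy-atom count and are both five-membered aromatic rings with 2 hetero atoms, but the entering ring has 1 hydrogen-bond donor and 1 hydrogen-bond acceptor where the leaving ring has 0 and 2, and this single pair cannot show which of these differences, if either, goes with the lower number. No measurement is at hand that would explain the step.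

Open, as far as these compounds go, is whether the same exchange gives a step of similar size with hydrogen in place of methoxy on the aromatic carbon, as in compound 3. Also open, from the compounds shown here alone, is how this place reads with a thienyl group or a primary amide in place of either ring.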